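A few compounds are considered here, and "the series" means these few. Any claim that something is new, unique, unknown or untested is made for them only; others in the source may bear on it.

Compound 2 `ClCc1ccccc1Cn1cnc2c(Cl)nc(Cl)nc21` gives the lowest number of the three measured compounds in a functional assay on NCI-H522 cells (Homo sapiens) for cytotoxicity, read by sulforhodamine B assay, with a stated time of 48 h (a higher number here means a weaker inhibitor of growth, a lower number a stronger inhibitor of growth), at 580 nM. Compound 1 `ClCc1ccc(Cn2cnc3c(Cl)ncnc32)cc1` gives 3540 nM in this assay, and compound 3 `Nc1nc(Cl)c2ncn(Cc3ccc(CCl)cc3)c2n1` gives 10900 nM. Among the compounds with values here, the one single-point step among them, a 3.1-fold higher number from compound 1 to compound 3 (0.49 log units; beyond the scatter), concerns a change on the same six-membered ring. Compound 4 `ClCc1ccccc1Cn1cnc2c(Cl)ncnc21` differs from compound 2 by hydrogen in place of chloro on an aromatic carbon, on the carbon between two ring nitrogen atoms. Within the data shown here, no measured pair shows this exact change, so the step from compound 1 to compound 3 is only indirect guidance, pointing to a modest weakening when that position is altered. Compound 4 is therefore expected to give a somewhat higher number than compound 2, the expected step being a 2.6-fold higher number from compound 2 to compound 4 (0.41 log units; beyond the scatter), with an estimate of 1500 nM in a range from 500 nM to 5000 nM.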

Compound 4, concentration for 50% growth inhibition: 1820 nM
The estimate for compound 4 lay 1.2-fold (0.08 log units) below the measured number, and the stated range covers the measured number.
By their numbers in this assay, from the lowest: compound 2; then compounds 4 and 1 (each within the scatter of the next); then compound 3.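

In this assay this carbon between two ring nitrogen atoms now has a direct reading, with chloro as the starting point: a 3.1-fold higher number from compound 2 to compound 4 (0.50 log units; beyond the scatter) shows a modest loss of growth inhibition when hydrogen replaces it. The earlier step at this carbon, a 3.1-fold higher number from compound 1 to compound 3 (0.49 log units; beyond the scatter), started from hydrogen and brought in amino, so it could not show what chloro contributes. Nothing available explains this step.

From the compounds shown here alone, whether a smaller fluoro or a methoxy group on this carbon would hold the number of compound 2 remains open. So does whether chloro there gives a similar step with the chloromethyl group placed as in compound 1.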